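Sulfonamide side-chain variation on a shared pyrrolopyridine-phenyl core

The source may hold more compounds than are shown below. What is called first, only, known or untested is meant among the compounds shown, and "the series" means these compounds.

The series is built on the core of compound 1 `O=S(=O)(NCCN1CCCCC1)c1ccc(-c2ccnc3[nH]ccc23)cc1`, which in an assay on isolated protein for inhibition of serine/threonine-protein kinase Nek1 (Homo sapiens), read by TR-FRET, with a stated time of 30 min (on this read-out higher numbers stand for weaker inhibition and lower numbers for stronger inhibition), gives 6600 nM. Compound 2 `CC(C)(C)OC(=O)NCCNS(=O)(=O)c1ccc(-c2ccnc3[nH]ccc23)cc1` carries a (tert-butoxycarbonyl)amino group on the chain and in this assay shows no result reported, so where compound 2 stands on the numbers shown cannot be said; compound 1 is the only reference point for the series.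

Compound 3 `CC(=O)OCCNS(=O)(=O)c1ccc(-c2ccnc3[nH]ccc23)cc1` is not yet measured. It differs from compound 2 by a single exchange: acetoxy in place of (tert-butoxycarbonyl)amino on a saturated chain carbon, two bonds along the chain from a sulfonamide nitrogen. Among the measured compounds shown here, because compound 2 has no value, no size of step from compound 2 to compound 3 can be read or computed, and none is given here.

Across the two measured and unmeasured chain variants the only anchor is compound 1 with 6600 nM, which points to weak inhibition in this region of the series. Compound 3 is therefore expected to sit in the same weak range, around 10000 nM, with a plausible span from 2500 nM to 40000 nM. A reported limit rather than a number is a real possibility for compound 3.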

Compound 3, half-maximal inhibitory concentration: 8800 nM
Compound 3: middle estimate off by 1.1-fold (0.06 log units), on the high side; the range from low to high includes it.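

In this assay, acetoxy in place of piperidin-1-yl on a saturated chain carbon, two bonds along the chain from a sulfonamide nitrogen, gives a 1.3-fold higher number from compound 1 to compound 3 (0.12 log units; within the scatter), which gives this position a second measured point. Two chain ends with different names and heavy-atom make-up therefore cannot be told apart on this read-out, and for this pair inhibition at the level of compound 1 does not depend on keeping piperidin-1-yl, with compound 3 at 8800 nM still a measured number. No available evidence bears on why the two compounds read alike.

Any step involving compound 2 cannot be read, so the (tert-butoxycarbonyl)amino group adds nothing to the comparison at this position. Two points on one position also leave open whether any group there moves the number beyond the scatter, for instance a primary amine, a carboxylic acid or a morpholine ring at the chain end, or a longer chain between the sulfonamide nitrogen and that end.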